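Replacing chloro with hydroxy in compound 3

This account rests on a few compounds, and the source may have more. Where it says the series, first, only, none or still open, it means among the compounds named here.

Values measured in a functional assay on CCRF-CEM cells (Homo sapiens) for inhibition, read by MTT assay, with a stated time of 72 h (a higher number here means a weaker inhibitor, a lower number a stronger inhibitor), are as follows
Compound 1 `COc1cc(NC(C)CCCNC(=O)Nc2cccc(Cl)c2)c2ncccc2c1` gives 22000 nM
Compound 2 `COc1cc(NC(C)CCCNC(=O)NNC(=O)Nc2ccc(F)cc2)c2ncccc2c1` gives 118000 nM
Compound 3 `COc1cc(NC(C)CCCNC(=O)Nc2ccc(Cl)cc2)c2ncccc2c1` gives 24000 nM

Compound 3 stands second highest of the three, level within the scatter with compound 1 and clearly lower than compound 2 (a 4.9-fold lower number from compound 2 to compound 3 (0.69 log units; beyond the scatter)). Compound 4 `COc1cc(NC(C)CCCNC(=O)Nc2ccc(O)cc2)c2ncccc2c1` differs from compound 3 in one place, with hydroxy in place of chloro on an aromatic carbon. Within the data shown here, no measured step makes this exchange, so the evidence is indirect. Exchanging one chlorophenyl for another left the number unmoved (a 1.1-fold higher number from compound 1 to compound 3 (0.04 log units; within the scatter)). The only larger shifts came with the far bigger change in compound 2 (a 5.4-fold higher number from compound 1 to compound 2 (0.73 log units; beyond the scatter)). In this assay a modest step towards a higher number is therefore expected, though one within the scatter remains possible. The expected step runs (a 1.5-fold higher number from compound 3 to compound 4 (0.16 log units; within the scatter)). Compound 4 is estimated at 35000 nM with an expected range from 13000 nM to 100000 nM overall.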

Compound 4, half-maximal inhibitory concentration: 23000 nM
Beside the measured number, compound 4's estimate is 1.5-fold (0.18 log units) above it, within the range that was stated.
By their numbers in this assay, from the lowest: compounds 1, 4 and 3 (each within the scatter of the next); then compound 2.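

In this assay, hydroxy and chloro on an aromatic carbon para to a large group read as level (a 1.0-fold lower number from compound 3 to compound 4 (0.02 log units; within the scatter)), so the substituent itself, not only its place on the ring as between compound 1 and compound 3, has now been exchanged without a step beyond the scatter. Compound 4 is also level with the meta-free comparison of the chlorophenyl series (a 1.0-fold higher number from compound 1 to compound 4 (0.02 log units; within the scatter)), and the step from the larger side chain keeps the size seen for the chlorophenyl compounds (a 5.1-fold lower number from compound 2 to compound 4 (0.71 log units; beyond the scatter)). Nothing in the data available here accounts for this lack of a difference.

On these data alone, whether an amine, a carboxylic acid or a methoxy group on this same aromatic carbon would also stay level remains open. So does whether any group at this position can give a step beyond the scatter towards a lower number.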